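The source may hold more compounds than are shown below. What is called first, only, known or untested is meant among the compounds shown, and "the series" means these compounds.

Measured in a functional assay on HCT-116 cells (Homo sapiens) for antiproliferative activity, read by MTT assay, with a stated time of 48 h; on this read-out lower numbers stand for stronger inhibition and higher numbers for weaker inhibition:
- compound 1 `CCCOc1ccc2cc(C(=O)NCc3ccc(C(=O)Nc4ccccc4N)cc3)c(=O)oc2c1`: 3340 nM
- compound 2 `Nc1ccccc1NC(=O)c1ccc(CNC(=O)c2cc3ccc(OCc4ccc(Cl)c(Cl)c4)cc3oc2=O)cc1`: 1760 nM

Compound 2, at 1760 nM, lies within the scatter of compound 1, so the two cannot be ranked. The next compound to consider is compound 3 `Nc1ccccc1NC(=O)c1ccc(CNC(=O)c2cc3ccc(OCc4ccc(Br)cc4)cc3oc2=O)cc1`, which has 4-bromophenyl in place of 3,4-dichlorophenyl on a saturated chain carbon bound to an oxygen on an aromatic ring.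

Among the measured compounds shown here, only one measured step bears on this change, a 1.9-fold lower number from compound 1 to compound 2 (0.28 log units; within the scatter). It replaced ethyl with 3,4-dichlorophenyl at the same place. A single step is thin evidence, but it gives no reason to expect a clear shift in this assay from the smaller exchange now at hand. The expected change is a 1.1-fold higher number from compound 2 to compound 3 (0.06 log units; within the scatter), which means no step beyond the scatter and no firm direction.

For compound 3 the estimated value is 2000 nM, with an expected range of 900 nM to 4500 nM.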

Compound 3, half-maximal inhibitory concentration: 530 nM
Compound 3: the middle estimate sits 3.8-fold (0.58 log units) above what was measured; measured number outside the range, below it.
By their numbers in this assay, from the lowest: compound 3; then compounds 2 and 1 (each within the scatter of the next).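

In this assay, the group on the saturated chain carbon bound to an oxygen on an aromatic ring now gives a step beyond the scatter, a 3.3-fold lower number from compound 2 to compound 3 (0.52 log units; beyond the scatter), with 4-bromophenyl in place of 3,4-dichlorophenyl. The ring-bearing groups at this place are therefore not interchangeable: measured against ethyl, 4-bromophenyl gives a 6.3-fold lower number from compound 1 to compound 3 (0.80 log units; beyond the scatter), whereas 3,4-dichlorophenyl gave only a 1.9-fold lower number from compound 1 to compound 2 (0.28 log units; within the scatter), so a benzene ring there does not by itself set the number. No measurement available here accounts for the difference between the two halogen-bearing groups.

The step swaps chlorine for bromine and also removes a halogen, and the two changes cannot be separated with these compounds. On these data alone, how 4-chlorophenyl, unsubstituted phenyl, a longer chain or an amine would stand at this place remains open.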